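Swapping the amino acid side chain for hydroxyethylamine

A few compounds are considered here, and "the series" means these few. Any claim that something is new, unique, unknown or untested is made for them only; others in the source may bear on it.

Measured in a functional assay on HepG2 cells (Homo sapiens) for antiproliferative activity, read by CCK-8 assay, with a stated time of 48 h; a higher number here means a weaker inhibitor, a lower number a stronger inhibitor:
compound 1 `COc1ccc(/C=C\c2cc(OC)c(OC)c(OC)c2)cc1OCc1ccc(CN2C[C@H](O)C[C@@H]2C(=O)O)cc1`: > 10000 nM (a limit)
compound 2 `COc1ccc(/C=C\c2cc(OC)c(OC)c(OC)c2)cc1OCc1ccc(CN2CCCCC2C(=O)O)cc1`: 3100 nM
compound 3 `COc1ccc(/C=C\c2cc(OC)c(OC)c(OC)c2)cc1OCc1ccc(CN[C@H](C(=O)O)[C@H](C)O)cc1`: > 10000 nM (a limit)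

Compound 3 reads > 10000 nM in this assay, and this value is a limit. Compound 3 thus sits at the limit of > 10000 nM in this assay, at which 2 of the 3 values shown sit.

Compound 4 `COc1ccc(/C=C\c2cc(OC)c(OC)c(OC)c2)cc1OCc1ccc(CNCCO)cc1` carries 2-hydroxyethyl in place of 1-carboxy-2-hydroxypropyl on an amine nitrogen.

For the measured compounds named here, no measured step makes this exact change, and all three measured compounds keep a carboxy group. The closest evidence is an at least 3.2-fold higher number from compound 2 to compound 3 (0.50 log units; beyond the scatter), where the (1-carboxy-2-hydroxypropyl)amino group enters. The step of an at least 3.2-fold lower number from compound 1 to compound 2 (0.50 log units; beyond the scatter) is of similar size, while a step that the two limits leave unreadable from compound 1 to compound 3 tells nothing about size. A modest fall in the number is therefore expected in this assay, although a second limit remains possible. Compound 2 reads 3100 nM, and a value in that region is the expectation here.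

The expected step is an at least 3.3-fold lower number from compound 3 to compound 4 (0.52 log units; beyond the scatter).

For compound 4 the estimate is 3000 nM, with an expected range of 500 nM to 10000 nM.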

Compound 4, half-maximal inhibitory concentration: 5900 nM
Compound 4: the middle estimate sits 2.0-fold (0.29 log units) below what was measured; low and high end bracket the measured number.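

In this assay, compound 4 is the only compound shown without a carboxy group, yet it gives a measured number rather than a limit, and against the 2-carboxypiperidin-1-yl group the (2-hydroxyethyl)amino group gives a 1.9-fold higher number from compound 2 to compound 4 (0.28 log units; within the scatter). Placing 2-hydroxyethyl on the amine nitrogen gives an at least 1.6-fold lower number from compound 3 to compound 4 (0.22 log units; that floor lies within the scatter), while the comparison with the 2-carboxy-4-hydroxypyrrolidin-1-yl group gives an at least 1.6-fold lower number from compound 1 to compound 4 (0.22 log units; that floor lies within the scatter). Compound 1 and compound 3 are limits, so these two steps are only floors and show no gain beyond the scatter: the limit of > 10000 nM in this assay, at which 2 of the 4 values shown sit.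

As far as these compounds go, how far compound 1 and compound 3 truly lie from compound 4 remains open. So does the part played by the hydroxy group of the 2-hydroxyethyl chain, which a plain ethyl group, a 2-methoxyethyl group or a longer hydroxyalkyl chain on this nitrogen would address.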